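This account rests on a few compounds, and the source may have more. Where it says the series, first, only, none or still open, it means among the compounds named here.

Compound 1 `CCN(C/C=C/C#CC(C)(C)C)Cc1cccc(OCCN(C)S(=O)(=O)c2ccc(F)cc2)c1`: 255 nM
Compound 2 `CCN(C/C=C/C#CC(C)(C)C)Cc1cccc(OCCN(C)S(=O)(=O)c2cc3ccccc3s2)c1`: 1800 nM
Compound 3 `CCCN(CCOc1cccc(CN(CC)C/C=C/C#CC(C)(C)C)c1)S(=O)(=O)c1cccs1`: 170 nM

All three compounds share one core and were tested in a functional assay on HepG2 cells for inhibition of squalene monooxygenase (Homo sapiens); on this read-out higher numbers stand for weaker inhibition and lower numbers for stronger inhibition. Compound 1 stands second highest of the three numbers. Compound 3 gives 170 nM, a gap within the scatter, so these two cannot be told apart. Among the compounds with values here, compound 2 gives 1800 nM, and the step of a 7.1-fold higher number from compound 1 to compound 2 (0.85 log units; beyond the scatter) is the only one-place change measured; it swaps the 4-fluorophenyl for a group of two aromatic rings and weakens inhibition.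

Compound 4 `CCN(C/C=C/C#CC(C)(C)C)Cc1cccc(OCCN(C)S(=O)(=O)c2cc(-c3ccsc3)cs2)c1` is not yet measured. It differs from compound 1 as follows: 4-(thiophen-3-yl)thiophen-2-yl in place of 4-fluorophenyl on a sulfonyl sulfur. Again the 4-fluorophenyl gives way to a group of two aromatic rings, here two five-membered ones. Compound 3 carries a single five-membered ring on the sulfonyl sulfur but also differs from compound 1 elsewhere, so it offers only a loose hint. Because a 7.1-fold higher number from compound 1 to compound 2 (0.85 log units; beyond the scatter) went toward weaker inhibition with a two-ring group, a smaller step in the same direction is expected here. For compound 4 the expected step is a 3.5-fold higher number from compound 1 to compound 4 (0.55 log units; beyond the scatter). Compound 4 is therefore estimated at 900 nM, likely between 300 nM and 3000 nM.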

Compound 4, half-maximal inhibitory concentration: 90 nM
The estimate for compound 4 lay 10-fold (1.00 log units) above the measured number; the measured number lies below the stated range.
By their numbers in this assay, from the lowest: compounds 4, 3 and 1 (each within the scatter of the next, the first and the last beyond it); then compound 2.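

Carrying two aromatic rings on the sulfonyl sulfur need not weaken inhibition in this assay: compound 2 had pointed that way, but a 2.8-fold lower number from compound 1 to compound 4 (0.45 log units; beyond the scatter) shows that a two-ring group can instead strengthen it. The two-ring groups also differ sharply from each other, with a 20-fold lower number from compound 2 to compound 4 (1.30 log units; beyond the scatter) separating them, so having two rings does not settle the outcome at this position; the identity of the group counts, at least for this pair. Nothing available here explains the difference between these groups.

As far as these compounds go, it remains open whether both rings of the 4-(thiophen-3-yl)thiophen-2-yl group are needed: a single five-membered ring appears only in compound 3, which also differs elsewhere. Also open, from the compounds shown here alone, is how a group carrying an amine or a carboxylic acid would fare on this sulfonyl sulfur.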